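The source may hold more compounds than are shown below. What is called first, only, known or untested is meant among the compounds shown, and "the series" means these compounds.

Compound 1, `CCCC(=O)Nc1ncc(-c2ccc(OC)cc2)n1C`: in a toxicity assay on THP-1 cells (Homo sapiens) for inhibition (a higher number here means that more compound is tolerated, a lower number that less compound is tolerated), compound 1 gives > 100000 nM, which is a limit of the assay rather than a number.
Compound 2, `COc1ccc(-c2cnc(NC(=O)c3ccccc3C#N)n2C)cc1`: in this assay compound 2 gives > 100000 nM, again a limit.
Compound 3, `COc1ccc(-c2cnc(NC(=O)c3ccc(F)cc3)n2C)cc1`: in this assay compound 3 gives >= 50000 nM, also a limit.

Compound 3 therefore stands at no measured number at all. All three values recorded in this assay are limits: the limit of > 100000 nM in this assay, at which 2 of the 3 values shown sit, and (the limit of >= 50000 nM in this assay, at which 1 of the 3 values shown sits). The steps between the measured compounds are accordingly unreadable: a step that the two limits leave unreadable from compound 1 to compound 3 and a step that the two limits leave unreadable from compound 2 to compound 3, both changes on the carbonyl carbon, and likewise a step that the two limits leave unreadable from compound 1 to compound 2. None of them tells how much a change on the carbonyl carbon alters tolerance, only that none of the three compounds reached a measurable toxic concentration.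

Compound 4, `COc1ccc(-c2cnc(NC(=O)c3ccc(Cl)cc3)n2C)cc1`, differs from compound 3 by a smaller change than any measured step: chloro in place of fluoro on an aromatic carbon. Within the data shown here, no measured step swaps one halogen for another, so the expectation for compound 4 rests on compound 3, whose limit >= 50000 nM is the nearest point of comparison. For compound 4 the step that the limit leaves unreadable from compound 3 to compound 4 is therefore expected to be none beyond the scatter. In this assay compound 4 is estimated at 80000 nM, with a range of 30000 nM to 150000 nM, and most likely the assay will again report only a limit.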

Compound 4, half-maximal cytotoxic concentration: > 100000 nM
Compound 4: only a limit was reported; the forecaster's own chance of this, stated with the estimate: 75%; middle value at least 1.2-fold (0.09 log units) away from the limit.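

Compound 4 also gives only a limit in this assay, so its steps from compound 1, compound 2 and compound 3 cannot be read: the limit of > 100000 nM in this assay, at which 3 of the 4 values shown sit.

The compounds shown leave open at what concentration, if any, these four compounds harm the cells, and how much chloro in place of fluoro alters tolerance.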